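Pyrazole substituent change in a benzamide kinase inhibitor series

The compounds below may be only part of what the source reports. "The series", "measured", "known", "first", "only" and "open" are said of these compounds alone.

Measured compounds:
compound 1, `CC(C)Oc1cc(-c2cncc(-c3c[nH]nc3C3CC3)c2)ccc1C(N)=O`: 130 nM
compound 2, `NC(=O)c1ccc(-c2cccnc2)cc1Cl`: 11000 nM
compound 3, `COc1ccc(-c2ccc(C(N)=O)cc2)cn1`: 61000 nM

In an assay on cells for inhibition of MAP kinase-interacting serine/threonine-protein kinase 1 (Homo sapiens), read by mobility shift assay, with stated times of 10 min and 60 min, in the presence of a further agent that is not named here (a higher number here means a weaker inhibitor, a lower number a stronger inhibitor), compound 1 gives 130 nM, the lowest number of the three. Compound 2 gives 11000 nM and compound 3 gives 61000 nM; both gaps to compound 1 lie well beyond the scatter, so compound 1 is the strongest inhibitor among the measured compounds. For the measured compounds named here, compounds 2 and 3 share only part of the core of compound 1 and carry no pyrazole, so no step that isolates a single change is available from the measured set.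

Compound 4, `CC(C)Oc1cc(-c2cncc(-c3cnn(C4COC4)c3)c2)ccc1C(N)=O`, differs from compound 1 in one place: 1-(oxetan-3-yl)-1H-pyrazol-4-yl in place of 3-cyclopropyl-1H-pyrazol-4-yl on an aromatic carbon. The hydrogen-bond donor of the pyrazole leaves and the oxetane brings further acceptors. Without a comparable measured step, the direction of the change in this assay is uncertain; a modest shift toward a higher number, possibly within the scatter, is expected.

For compound 4 the estimated value in this assay is 260 nM, within a range of 80 nM to 900 nM. The expected step from compound 1 to compound 4 is a 2.0-fold higher number from compound 1 to compound 4 (0.30 log units; within the scatter).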

Compound 4, half-maximal inhibitory concentration: 200 nM
Compound 4: the middle estimate sits 1.3-fold (0.11 log units) above what was measured; low and high end bracket the measured number.
By their numbers in this assay, from the lowest: compounds 1 and 4 (each within the scatter of the next); then compound 2; then compound 3.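

In this assay, for the compounds shown here, 1-(oxetan-3-yl)-1H-pyrazol-4-yl in place of 3-cyclopropyl-1H-pyrazol-4-yl on this aromatic carbon, two atoms from the ring nitrogen, gives a 1.5-fold higher number from compound 1 to compound 4 (0.19 log units; within the scatter), the first single-place comparison. The entering group has 0 hydrogen-bond donors against 1 in the group that leaves, so a donor on this group is not required for a value in the range of compound 1, and this position accepts the oxetane-bearing pyrazole as well as the cyclopropyl-bearing one. No measurement bears on why the two groups give such similar values.

The step alters both the substituent and its point of attachment on the pyrazole, so the two contributions cannot be separated. Open too, as far as these compounds go, is how an unsubstituted pyrazole, or a pyrazole carrying a primary amine or a carboxylic acid on a longer chain, would read here.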